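Adding an Ethynyl Group to Compound 3

This account rests on a few compounds, and the source may have more. Where it says the series, first, only, none or still open, it means among the compounds named here.

In a functional assay on SK-MEL-28 cells (Homo sapiens) for inhibition, read by colorimetric assay and MTT assay, with a stated time of 72 h (a lower number here means a stronger inhibitor, a higher number a weaker inhibitor), compound 1 (`Cc1ccc2c(c1)-c1cnc(n1C)OCCCCCCCCO2`) gives 55000 nM as its half-maximal inhibitory concentration, compound 2 (`Cn1c2cnc1OCCCCCCCCOc1cc(F)ccc1-2`) gives 58000 nM and compound 3 (`CCCCOc1ncc(-c2ccccc2OC)n1C`) gives 82000 nM on the same read-out. These three numbers all lie within the usual scatter of repeated measurements, so compound 3 cannot be told apart from the other two. This holds even though its chain is open, whereas compound 1 and compound 2 carry a closed one.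

Compound 4 (`C#CCCCCOc1ncc(-c2ccccc2OC)n1C`) is compound 3 with ethynyl in place of hydrogen on a saturated chain carbon, four bonds along the chain from an oxygen on an aromatic ring. For the measured compounds named here, no measured pair shows what this change does, so the expectation rests on compound 3 at 82000 nM and on how closely the three numbers agree. In this assay the expected change a 1.3-fold lower number from compound 3 to compound 4 (0.10 log units; within the scatter) is no step beyond the scatter, in either direction. For compound 4 the estimated value is 65000 nM (expected range 30000 nM to 130000 nM).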

Compound 4, half-maximal inhibitory concentration: 38000 nM
Compound 4: middle estimate off by 1.7-fold (0.23 log units), on the high side; measured number inside the range.
By their numbers in this assay, from the lowest: compounds 4, 1, 2 and 3 (each within the scatter of the next, the first and the last beyond it).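

Unlike the three earlier numbers, which could not be told apart, ethynyl in place of hydrogen on this saturated chain carbon gives a step in this assay that can be read: a 2.2-fold lower number from compound 3 to compound 4 (0.33 log units; beyond the scatter). This shows that the open chain of compound 3 is a place where a small change of two carbons and one triple bond, with no hydrogen-bond donor or acceptor, can shift the number, although only modestly. Nothing shown here explains why the number falls.

Going by these compounds, what remains open is whether the triple bond matters or the added chain length alone would do the same, a question that a plain hexyl chain at this place would address. On these data alone, it is also open how an amine or a carboxylic acid at the end of the chain would compare with ethynyl.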